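Nitrophenyl in Place of Pyridinyl on the Ring Amine

This account rests on a few compounds, and the source may have more. Where it says the series, first, only, none or still open, it means among the compounds named here.

Compound 1 `CC#CC(CC(=O)O)c1ccc(OCc2ccc(C(=O)N3CCN(c4ccccn4)CC3)s2)cc1` gives 138 nM in a functional assay on HEK293 cells for agonist activity at Free fatty acid receptor 1 (Homo sapiens), read by fluorescence and calcium flux (on this read-out higher numbers stand for an effect only at larger amounts of compound and lower numbers for an effect already at smaller amounts), the lowest of the three numbers, although compound 3 `CC#CC(CC(=O)O)c1ccc(OCc2ccc(C(=O)N3CCN(c4ccc([N+](=O)[O-])cc4)CC3)s2)cc1` with 231 nM sits within the scatter of it, while compound 2 `CC#CC(CC(=O)O)c1ccc(OCc2ccc(C(=O)N3CCN(c4ccc(C(C)(C)C)cc4)CC3)s2)cc1` gives 417 nM. Compound 4 `CC#CC(CC(=O)O)c1ccc(OCc2ccc(C(=O)N3CCN(c4cccc([N+](=O)[O-])c4)CC3)s2)cc1` differs from compound 1 in one place: 3-nitrophenyl in place of pyridin-2-yl on an amine nitrogen in a ring. Going by the values given here, two measured steps bear on this change, both replacing the same pyridin-2-yl group on the ring nitrogen: a 3.0-fold higher number from compound 1 to compound 2 (0.48 log units; beyond the scatter), and a 1.7-fold higher number from compound 1 to compound 3 (0.22 log units; within the scatter). Both moved toward higher numbers, and because a 3.0-fold higher number from compound 1 to compound 2 (0.48 log units; beyond the scatter) was beyond the scatter while the nitro-bearing step was not, a modest rise is expected for compound 4, a 1.7-fold higher number from compound 1 to compound 4 (0.24 log units; within the scatter). Compound 4 is therefore estimated at 240 nM, with a range from 110 nM to 500 nM.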

Compound 4, half-maximal effective concentration: 187 nM
Beside the measured number, compound 4's estimate is 1.3-fold (0.11 log units) above it; measured number inside the range.
By their numbers in this assay, from the lowest: compounds 1, 4, 3 and 2 (each within the scatter of the next, the first and the last beyond it).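

The position tolerates the nitro group in either placement: in this assay, 3-nitrophenyl and 4-nitrophenyl cannot be told apart (a 1.2-fold lower number from compound 3 to compound 4 (0.09 log units; within the scatter)). 3-Nitrophenyl also stays level with pyridin-2-yl (a 1.4-fold higher number from compound 1 to compound 4 (0.13 log units; within the scatter)). It does stand clear of 4-(tert-butyl)phenyl (a 2.2-fold lower number from compound 2 to compound 4 (0.35 log units; beyond the scatter)), a separation that 4-nitrophenyl, within the scatter of compound 2, does not show.

From the compounds shown here alone, whether an amine or a carboxylic acid in place of the nitro group would stand clear of compound 1 remains open. Nothing available explains these numbers.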